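Replacing the imidazole on compound 2 by a dimethylamino group

The compounds below may be only part of what the source reports. "The series", "measured", "known", "first", "only" and "open" are said of these compounds alone.

Measured compounds:
compound 1 `O=C(c1ccc(C2CCCCC2)cc1)N1CC(O)C1` gives 26 10^-6 cm/s
compound 2 `O=C(Cn1ccnc1)Nc1ccc(C2CCCCC2)cc1` gives 11.1 10^-6 cm/s
compound 3 `O=C(c1ccc([C@H]2[C@@H](F)[C@@H](F)C[C@@H](F)[C@H]2F)cc1)N1CC(O)C1` gives 6.7 10^-6 cm/s

These three compounds were measured in an ADME assay on MDCK-MDR1 cells (Canis lupus familiaris) for permeability, in the apical to basolateral direction, with a stated time of 180 min; a higher number here means that the compound crosses the layer faster, a lower number that the compound crosses the layer more slowly. Compound 2 stands second highest of the three numbers. Its nearest neighbour is compound 3, whose value lies within the scatter of that of compound 2, so no order between the two can be read from the data. Compound 1 lies furthest from compound 2, with a higher number beyond the scatter.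

The compound to be measured next is compound 4 `CN(C)CCC(=O)Nc1ccc(C2CCCCC2)cc1`. It differs from compound 2 in one place: (dimethylamino)methyl in place of 1H-imidazol-1-yl on a saturated chain carbon bound to a carbonyl carbon. Among the compounds with values here, no pair of measured compounds shows exactly this change, so its size and direction have not been observed here. The author expects a modest step, a 1.4-fold lower number from compound 2 to compound 4 (0.14 log units; within the scatter), leaning toward a lower number but likely not beyond the scatter, resting on the value of compound 2 at 11.1 10^-6 cm/s. For compound 4 in this assay the estimate is 8 10^-6 cm/s, with a range from 3 10^-6 cm/s to 20 10^-6 cm/s.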

Compound 4, apparent permeability: 10.8 10^-6 cm/s
Beside the measured number, compound 4's estimate is 1.4-fold (0.13 log units) below it; the measured number falls inside the stated range.
By their numbers in this assay, from the lowest: compounds 3, 4 and 2 (each within the scatter of the next); then compound 1.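

In this assay, within the data shown here, the change of 1H-imidazol-1-yl to (dimethylamino)methyl on a saturated chain carbon bound to a carbonyl carbon gives a 1.0-fold lower number from compound 2 to compound 4 (0.01 log units; within the scatter) and is the only step between measured compounds that differ in one place. It shows that, in this one pair, a five-membered aromatic ring with 2 hetero atoms can give way to a group with no ring while the number stays within the scatter. No measurement shown here offers an explanation for this result.

This single step does not tell whether a morpholine, a piperidine or a carboxylic acid at the same place, or a longer chain ending in the dimethylamino group, would also stay within the scatter. It also leaves open whether the same change would read alike on another core.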